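The compounds below may be only part of what the source reports. "The series", "measured", "known", "first", "only" and "open" are said of these compounds alone.

Compound 1 `C/C=C/C=C/C(=O)N[C@H](C(=O)NCCCCCCCCCCCCCC)[C@@H](C)O`. In a functional assay on A-431 cells (Homo sapiens) for cytotoxicity, read by MTT assay, with a stated time of 48 h (a lower number here means a stronger inhibitor, a higher number a weaker inhibitor), compound 1 gives > 200000 nM, which is a limit of the assay rather than a number.
Compound 2 `CCCCCCCCCCCCCCNC(=O)[C@@H](NS(=O)(=O)c1ccc(C)cc1)[C@@H](C)O`. In this assay compound 2 gives 12000 nM.
Compound 3 `C/C=C/C=C/C(=O)N[C@H](C(=O)NCCCCCCCCCCCCCCCCCC)[C@@H](C)O`. In this assay compound 3 gives 187000 nM.

Compound 3 differs from compound 1 in its chain: butyl in place of hydrogen on a saturated chain carbon, ten or more bonds along the chain from an amide-type nitrogen. That change gave an at least 1.0-fold lower number from compound 1 to compound 3 (0.02 log units; that floor lies within the scatter), so the two chain lengths behave alike here. The change of interest is (4-methylphenyl)sulfonyl in place of (penta-1,3-dien-1-yl)carbonyl on an amine nitrogen, which gave an at least 16-fold lower number from compound 1 to compound 2 (1.22 log units; beyond the scatter).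

Compound 4 `CCCCCCCCCCCCCCCCCCNC(=O)[C@@H](NS(=O)(=O)c1ccc(C)cc1)[C@@H](C)O` is not yet measured. It carries the same change relative to compound 3: (4-methylphenyl)sulfonyl in place of (penta-1,3-dien-1-yl)carbonyl on an amine nitrogen. The place is described in the same words for both pairs, so this is the same change on a longer chain. Since the chain length made little difference between compound 1 and compound 3, a step of similar size is expected, namely a 16-fold lower number from compound 3 to compound 4 (1.19 log units; beyond the scatter). Compound 4 is therefore estimated to give 12000 nM, most likely between 4000 nM and 40000 nM.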

Compound 4, half-maximal inhibitory concentration: 34000 nM
Estimate against measurement, compound 4: 2.8-fold (0.45 log units) below; the measured number falls inside the stated range.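

In this assay the swap to (4-methylphenyl)sulfonyl lowers the number on the longer chain too, a 5.5-fold lower number from compound 3 to compound 4 (0.74 log units; beyond the scatter), so the direction carries from one core to the other, but the size does not: the same change on two cores in this assay, an at least 16-fold lower number (1.22 log units; beyond the scatter) from compound 1 to compound 2 and a 5.5-fold lower number (0.74 log units; beyond the scatter) from compound 3 to compound 4, at least 3.0-fold (0.48 log units) apart, beyond the scatter of two such steps
Lengthening the chain also matters once the sulfonyl group is present, a 2.8-fold higher number from compound 2 to compound 4 (0.45 log units; beyond the scatter), which the pair carrying (penta-1,3-dien-1-yl)carbonyl did not show: the same change on two cores in this assay, an at least 1.0-fold lower number (0.02 log units; that floor lies within the scatter) from compound 1 to compound 3 and a 2.8-fold higher number (0.45 log units; beyond the scatter) from compound 2 to compound 4, at least 3.0-fold (0.48 log units) apart, beyond the scatter of two such steps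
The true size of the first step stays unknown, since compound 1 sits at a limit of the assay: the limit of > 200000 nM in this assay, at which 1 of the 4 values shown sits.

As far as these compounds go, whether a shorter chain, or a benzoyl group on that amine nitrogen, would follow the same course remains open. Two chain lengths and two groups are too few to define a trend.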